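Working notes: a brominated aldehyde variant of compound 3

A few compounds are considered here, and "the series" means these few. Any claim that something is new, unique, unknown or untested is made for them only; others in the source may bear on it.

Three compounds have been run in a functional assay on HT-29 cells (Homo sapiens) for cytotoxicity, read by MTT assay, with a stated time of 24 h; on this read-out lower numbers stand for stronger inhibition and higher numbers for weaker inhibition. Compound 1 `C#CCOc1cc(N(CC)CC)ccc1/C=N/Cc1ccc(S(N)(=O)=O)cc1` gives 62800 nM in this assay. Compound 2 `C#CCOc1ccc(/C=N/Cc2ccc(S(N)(=O)=O)cc2)cc1OC` gives 136000 nM. Compound 3 `O=Cc1cccc(OCc2cn(CCCOc3ccc4ccc(=O)oc4c3)nn2)c1` gives 129000 nM, the second highest of the three numbers; the number for compound 2 lies within the scatter of it, while the number for compound 1 is lower and beyond the scatter. All three numbers sit at the weak end of inhibition.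

Compound 4 `O=Cc1cc(Br)ccc1OCc1cn(CCCOc2ccc3ccc(=O)oc3c2)nn1` has not yet been measured. It differs from compound 3 by 4-bromo-2-formylphenyl in place of 3-formylphenyl on an oxygen on a saturated carbon. No pair of measured compounds differs in a single place, so there is no measured precedent for the size of a change of this kind in this assay. The expectation is a small step, direction uncertain, not beyond the scatter: the step is expected to read a 1.2-fold lower number from compound 3 to compound 4 (0.07 log units; within the scatter). Compound 4 is accordingly estimated at 110000 nM, with a range from 45000 nM to 260000 nM.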

Compound 4, half-maximal inhibitory concentration: 7470 nM
Beside the measured number, compound 4's estimate is 15-fold (1.17 log units) above it; the measured number lies below the stated range.
By their numbers in this assay, from the lowest: compound 4; then compound 1; then compounds 3 and 2 (each within the scatter of the next).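

Swapping the aryl group at this place, on an oxygen on a saturated carbon, can move the number in this assay well beyond the scatter: 4-bromo-2-formylphenyl in place of 3-formylphenyl gives a 17-fold lower number from compound 3 to compound 4 (1.24 log units; beyond the scatter), the first measured single-place step in the series. The size of this step comes with no change in the counted hydrogen-bond donors or acceptors of the group, and the formyl group and the six-membered aromatic ring remain. Nothing measured here accounts for the size of the step.

The step combines the entering bromine with the changed place of the formyl group, and the compounds shown do not separate the two. They also leave open whether chlorine or a methyl group in place of the bromine, or a carboxylic acid in place of the formyl group, would keep the lower number.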